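Methyl to trifluoromethyl on two small carboxylic acid cores

This account rests on a few compounds, and the source may have more. Where it says the series, first, only, none or still open, it means among the compounds named here.

Compound 1 `Cc1cc(C(=O)O)c[nH]1` and compound 3 `Cc1cccc(N2CCC(C(=O)O)C2)c1` are small carboxylic acids on different cores; the difference between the two cores is not broken down here. In an assay on cells for inhibition of Palmitoleoyl-protein carboxylesterase NOTUM variant C330S (Homo sapiens), read by fluorescence, with a stated time of 40 min (a higher number here means a weaker inhibitor, a lower number a stronger inhibitor), compound 1 gives 100000 nM. Compound 3 gives 49000 nM in this assay, the lowest of the two numbers, with the gap to compound 1 just beyond the scatter. Compound 2 `O=C(O)c1c[nH]c(C(F)(F)F)c1` carries the change (trifluoromethyl in place of methyl on an aromatic carbon). In this assay compound 2 reaches only a limit of the assay, > 100000 nM. The step of a number no lower from compound 1 to compound 2 (the limit leaves the size open) has no readable size; it is left open by the limit of > 100000 nM in this assay, at which 1 of the 3 values shown sits. Compound 4 `O=C(O)C1CCN(c2cccc(C(F)(F)F)c2)C1` bears the same kind of change on the core of compound 3, (trifluoromethyl in place of methyl on an aromatic carbon); the surroundings differ, the change sitting on a six-membered aromatic ring of carbon only, meta to a group of 8 heavy atoms, rather than on a five-membered aromatic ring with 1 nitrogen, next to the ring nitrogen. The step from compound 3 to compound 4 is expected to be a 1.3-fold higher number from compound 3 to compound 4 (0.12 log units; within the scatter), resting on compound 1 and compound 2, whose step a number no lower from compound 1 to compound 2 (the limit leaves the size open) points no lower. Compound 4 is estimated at 65000 nM in this assay, between 20000 nM and 200000 nM.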

Compound 4, half-maximal inhibitory concentration: 11000 nM
Compound 4: middle estimate off by 5.9-fold (0.77 log units), on the high side; the whole stated range lies above it.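

On the core of compound 3, trifluoromethyl in place of methyl on an aromatic carbon gives a 4.5-fold lower number from compound 3 to compound 4 (0.65 log units; beyond the scatter) in this assay. Set beside the same change on the core of compound 1, this step shows that the outcome does not carry over unchanged from one core to the other: the same change on two cores in this assay, a number no lower (the limit leaves the size open) from compound 1 to compound 2 and a 4.5-fold lower number (0.65 log units; beyond the scatter) from compound 3 to compound 4, at least 4.4-fold (0.64 log units) apart, beyond the scatter of two such steps

Compound 2 stands at a limit of the assay, > 100000 nM, so the size of the step on its core cannot be read, and a single pair on each core gives neither a general rule for further cores nor a reason for the gap: the limit of > 100000 nM in this assay, at which 1 of the 4 values shown sits.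

Still open, going by these compounds, is whether a nitrile, a chlorine or an ethyl group in the same place would follow trifluoromethyl on either core. Also open, on these data alone, is whether the lower number of compound 4 would persist with an amide in place of the carboxylic acid.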